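Chloro for Methoxy on a Weakly Cytotoxic Bis-arylidene Ketone

A few compounds are considered here, and "the series" means these few. Any claim that something is new, unique, unknown or untested is made for them only; others in the source may bear on it.

Compound 1 `COc1ccc(/C=C2\CCC/C(=C\c3ccc([N+](=O)[O-])cc3)C2=O)cc1` gives the highest number among the three compounds measured in a functional assay on CCRF-CEM cells (Homo sapiens) for cytotoxicity, with a stated time of 72 h (on this read-out higher numbers stand for weaker inhibition and lower numbers for stronger inhibition), namely 250000 nM. Its nearest neighbour is compound 3 `O=C1CCCC/C1=C\c1ccc([N+](=O)[O-])cc1`, whose value in this assay is 19300 nM, a gap well beyond the scatter. Furthest away is compound 2 `Cc1ccc(/C=C2\CCC/C(=C\c3cccc([N+](=O)[O-])c3)C2=O)cc1`, which in this assay gives 10100 nM, again beyond the scatter. Compound 1 therefore stands apart as the weakest inhibitor of the set, with both other compounds clearly stronger.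

The step to compound 4 `O=C1/C(=C/c2ccc(Cl)cc2)CCC/C1=C\c1ccc([N+](=O)[O-])cc1` replaces one substituent on the shared core of compound 1 and is otherwise unchanged: chloro in place of methoxy on an aromatic carbon. The change sits on an aromatic carbon of a six-membered aromatic ring of carbon only, para to a large group, so the rest of the molecule is kept as it stands.

Within the data shown here, no measured pair shows this exact change, so the expectation rests on the spread of the three values alone. Because compound 2 reaches 10100 nM and compound 3 reaches 19300 nM, compound 1 looks like the outlier of the set, and the estimate for compound 4 is a move toward those two, a step of a 10-fold lower number from compound 1 to compound 4 (1.00 log units; beyond the scatter) beyond the scatter and downward. Compound 4 is accordingly expected to give about 25000 nM in this assay, within a range from 6000 nM to 120000 nM.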

Compound 4, half-maximal inhibitory concentration: 8180 nM
Estimate against measurement, compound 4: 3.1-fold (0.49 log units) above, within the range that was stated.
By their numbers in this assay, from the lowest: compounds 4, 2 and 3 (each within the scatter of the next, the first and the last beyond it); then compound 1.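

Read in this assay, chloro in place of methoxy on this aromatic carbon, para to a large group, gives a 31-fold lower number from compound 1 to compound 4 (1.49 log units; beyond the scatter) and is the largest kind of change the set can show at a single site. The earlier compounds shown here could not show this, since no two of them differed in one place only, and their spread said nothing about any one substituent. Compound 4 now shows that the high number of compound 1 depends on this position: going from 4-methoxyphenyl to 4-chlorophenyl, with the rest of the molecule kept as it stands, is enough to lower the number by that step. Nothing measured here accounts for the size of this step.

Among these compounds, the single pair leaves open whether the drop follows from the arrival of chloro or from the departure of methoxy, and a plain hydrogen, a fluoro or a dimethylamino group at the same carbon would help to tell these apart. It also leaves open whether the same exchange would give a step of similar size on another core or in other cells.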